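The source may report more compounds than this note shows. Statements on the series, on what has been measured and on what is new or still open speak of the compounds shown alone.

Values in an ADME assay on microsomes (Homo sapiens) for metabolic stability; on this read-out higher numbers stand for fast clearance and lower numbers for slow clearance:

compound 1 `Cc1cc(C(F)(F)F)c2cccc(OCc3c(Cl)ccc(S(=O)(=O)N4CCC[C@H]4CO)c3Cl)c2n1` gives 250 mL/min/kg
compound 2 `Cc1cc(C(F)(F)F)c2cccc(OCc3c(Cl)ccc(S(=O)(=O)N4CCCCC4)c3Cl)c2n1` gives 233 mL/min/kg
compound 3 `Cc1cc(C(F)(F)F)c2cccc(OCc3c(Cl)ccc(S(=O)(=O)N4CCC(CCO)CC4)c3Cl)c2n1` gives 367 mL/min/kg

Compound 3, at 367 mL/min/kg, stands within the scatter of both other compounds, so the three values form a single group. The next structure is compound 4 `Cc1cc(C(F)(F)F)c2cccc(OCc3c(Cl)ccc(S(=O)(=O)N4C[C@@H](C)O[C@@H](C)C4)c3Cl)c2n1`, which has 2,6-dimethylmorpholin-4-yl in place of 4-(2-hydroxyethyl)piperidin-1-yl on a sulfonyl sulfur. Within the data shown here, none of the measured compounds carries the entering group, so no measured step shows this exact exchange. The nearest evidence comes from the other exchanges at the same sulfonyl sulfur. These are a 1.1-fold lower number from compound 1 to compound 2 (0.03 log units; within the scatter), a 1.5-fold higher number from compound 1 to compound 3 (0.17 log units; within the scatter) and a 1.6-fold higher number from compound 2 to compound 3 (0.20 log units; within the scatter). All three are small, and none of compounds 1, 2 and 3 goes against this picture. In this assay the expected change is therefore none beyond the scatter, namely a 1.3-fold lower number from compound 3 to compound 4 (0.12 log units; within the scatter). For compound 4 the estimated value is 280 mL/min/kg, with an expected range from 160 mL/min/kg to 480 mL/min/kg.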

Compound 4, clearance: 317 mL/min/kg
For compound 4 the middle estimate is 1.1-fold (0.05 log units) below the measured one; the range from low to high includes it.
By their numbers in this assay, from the lowest: compounds 2, 1, 4 and 3 (each within the scatter of the next).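

In this assay the entry of 2,6-dimethylmorpholin-4-yl on a sulfonyl sulfur stays within the scatter of all three earlier compounds (a 1.2-fold lower number from compound 3 to compound 4 (0.06 log units; within the scatter); a 1.4-fold higher number from compound 2 to compound 4 (0.13 log units; within the scatter); a 1.3-fold higher number from compound 1 to compound 4 (0.10 log units; within the scatter)). A second hetero atom in the six-membered ring, together with two defined stereocentres, therefore adds no step beyond the scatter, and all four values remain a single group at this position. Nothing measured here accounts for this flat picture.

As far as these compounds go, whether a carboxylic acid or a primary amine in the same place would move the number beyond the scatter remains open, as does the outcome of any change to the shared core. The compounds shown also do not separate the contribution of the ring oxygen from that of the two methyl groups.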